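The source may report more compounds than this note shows. Statements on the series, on what has been measured and on what is new or still open speak of the compounds shown alone.

Measured in a functional assay on THP-1 cells (Homo sapiens) for antiproliferative activity, read by MTT assay, with a stated time of 72 h; a lower number here means a stronger inhibitor, a higher number a weaker inhibitor:
- Compound 1 `CCc1cccc(NC(=O)C(=O)[C@H](CC(C)C)NC(=O)[C@H](CC(C)C)NC(=O)[C@H](CC(C)C)NC(=O)OCc2ccccc2)c1`: 71.1 nM
- Compound 2 `COc1cc(NC(=O)C(=O)[C@H](CC(C)C)NC(=O)[C@H](CC(C)C)NC(=O)[C@H](CC(C)C)NC(=O)OCc2ccccc2)cc(OC)c1`: 70.7 nM

Compound 2, at 70.7 nM, stands level with compound 1, at 71.1 nM, so neither can be ranked above the other in this assay. The next compound to be tested is compound 3 `CC(C)C[C@H](NC(=O)OCc1ccccc1)C(=O)N[C@@H](CC(C)C)C(=O)N[C@@H](CC(C)C)C(=O)C(=O)Nc1ccccc1`, which has a single structural change from compound 2: phenyl in place of 3,5-dimethoxyphenyl on an amide-type nitrogen. Put simply, phenyl takes the place of 3,5-dimethoxyphenyl on an amide-type nitrogen.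

Among the compounds with values here, one measured step bears on this, as it concerns the same amide-type nitrogen: a 1.0-fold lower number from compound 1 to compound 2 (0.00 log units; within the scatter). That step lies within the scatter, so these two different aromatic groups gave values that cannot be told apart. Neither measured compound carries a plain phenyl at this place, so the expectation rests on thin evidence and needs a wide range. No shift beyond the scatter is expected, and the estimated step is a 1.1-fold higher number from compound 2 to compound 3 (0.03 log units; within the scatter). For compound 3 the expected value is 75 nM, with an estimated range from 28 nM to 200 nM.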

Compound 3, half-maximal inhibitory concentration: 88.1 nM
The estimate for compound 3 lay 1.2-fold (0.07 log units) below the measured number, within the range that was stated.
By their numbers in this assay, from the lowest: compounds 2, 1 and 3 (each within the scatter of the next).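

Within the data shown here, compound 3 gives the first reading for a plain phenyl on this amide-type nitrogen in this assay, and its comparison with the 3,5-dimethoxyphenyl group is a 1.2-fold higher number from compound 2 to compound 3 (0.10 log units; within the scatter), so for this pair the two methoxy groups make no difference that can be told from the scatter. The comparison with the 3-ethylphenyl group, where hydrogen stands in place of ethyl on an aromatic carbon, is a 1.2-fold higher number from compound 1 to compound 3 (0.09 log units; within the scatter) and likewise shows that the ethyl group makes no measurable difference, which means that all three aromatic groups shown cannot be told apart in this assay. No measured information is available to account for this flat reading.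

On these data alone, all three groups are uncharged, six-membered aromatic rings of carbon only, so it remains open whether the values would hold with a pyridine ring on this nitrogen or with an amine or a carboxylic acid on the phenyl ring. As far as these compounds go, it also remains open whether a non-aromatic group on the same nitrogen, such as cyclohexyl or a butyl chain, would stay in this range.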